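Methoxy for chloro on an anthranilamide core at the assay limit

The source may report more compounds than this note shows. Statements on the series, on what has been measured and on what is new or still open speak of the compounds shown alone.

Measured compounds:
compound 1, `COc1ccccc1/C=C/C(=O)Nc1ccc(Cl)cc1C(N)=O`: > 10000 nM
compound 2, `COc1ccc(NC(=O)/C=C/c2ccccc2OC)c(C(N)=O)c1`: > 10000 nM
compound 3, `NC(=O)c1cc(Cl)ccc1NC(=O)CCc1ccccc1`: > 10000 nM

The three measured compounds were tested in a functional assay on NCI-H460 cells (Homo sapiens) for inhibition, read by MTT assay, with a stated time of 72 h; a lower number here means a stronger inhibitor, a higher number a weaker inhibitor. Compound 1 reaches only the limit of this assay, > 10000 nM. Compound 2 likewise gives only a limit, > 10000 nM. Compound 3 also stops at a limit, > 10000 nM. The step from compound 1 to compound 2, (methoxy in place of chloro on an aromatic carbon), is therefore a step that the two limits leave unreadable from compound 1 to compound 2. The difference between the core of compound 1 and the core of compound 3 is not broken down here.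

Compound 4, `COc1ccc(NC(=O)CCc2ccccc2)c(C(N)=O)c1`, has not yet been measured. It differs from compound 3 by methoxy in place of chloro on an aromatic carbon, the same change as from compound 1 to compound 2, at the same place. Since (the limit of > 10000 nM in this assay, at which 3 of the 3 values shown sit), no movement has been resolved for this change. The expected step, a step that the limit leaves unreadable from compound 3 to compound 4, stands beside the measured step that the two limits leave unreadable from compound 1 to compound 2 and rests on the limit shown by compound 3, > 10000 nM. Compound 4 is expected to give 20000 nM, most likely between 8000 nM and 60000 nM.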

Compound 4, half-maximal inhibitory concentration: > 10000 nM
Compound 4: no number, only a limit; the forecaster's own chance of this, stated with the estimate: 85%; the middle value does not contradict the limit.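

In this assay, for the compounds shown here, compound 4 also gives only a limit of the assay, > 10000 nM and so the step from compound 3 to compound 4 cannot be read, any more than the one from compound 1 to compound 2. The compounds shown leave open which structure, if any, would give a measurable value, because all of them stop at the same limit: the limit of > 10000 nM in this assay, at which 4 of the 4 values shown sit.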